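The compounds below may be only part of what the source reports. "The series", "measured", "known", "first", "only" and "open" are said of these compounds alone.

Measured so far:
Compound 1 `Cc1ccccc1CNc1nn(-c2ccc(F)cc2F)cc1CNCCN1CCN(C)CC1`: > 20000 nM
Compound 2 `CN1CCN(CCNCc2cn(-c3ccc([N+](=O)[O-])cc3)nc2-c2ccc(Cl)cc2)CC1`: 5000 nM

In an ADME assay on Huh-7 cells (Homo sapiens) for cytotoxicity (a higher number here means that more compound is tolerated, a lower number that less compound is tolerated), compound 1 gives > 20000 nM; this is a limit of the assay, not a number, and (the limit of > 20000 nM in this assay, at which 1 of the 2 values shown sits). Compound 2 gives 5000 nM in this assay. For the measured compounds named here, no computed step links these two compounds, so their values stand side by side only.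

Compound 3 `CN1CCN(CCNCc2cn(-c3ccc(F)cc3F)nc2C(C)(C)C)CC1` differs from compound 1 in one place: tert-butyl in place of (2-methylbenzyl)amino on an aromatic carbon. Going by the values given here, no measured step guides this change, so the expected step of a number no higher from compound 1 to compound 3 (the limit leaves the size open) is one of no change beyond the scatter. Compound 3 is estimated at 20000 nM, within a range from 8000 nM to 40000 nM.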

Compound 3, half-maximal cytotoxic concentration: > 20000 nM
Compound 3 gave a limit, no number (the forecaster's own chance of this, stated with the estimate: 50%); the middle value sits exactly at the limit.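

In this assay, for the compounds shown here, compound 1 and compound 3 both give a limit rather than a number, so no step between them can be read. From the compounds shown here alone, whether tert-butyl in place of (2-methylbenzyl)amino changes how much compound is tolerated stays open.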